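The source may hold more compounds than are shown below. What is called first, only, known or untested is meant among the compounds shown, and "the series" means these compounds.

Measured so far in a functional assay on SK-BR-3 cells (Homo sapiens) for antiproliferative activity; a higher number here means a weaker inhibitor, a lower number a stronger inhibitor:
compound 1, `CC(C)=CCc1cc(C(=O)Nc2cc3ccc(OCC4CCN(C)C4)c(C)c3oc2=O)ccc1O`, 920 nM
compound 2, `CCN(C)CCCOc1ccc2cc(NC(=O)c3ccc(O)c(CC=C(C)C)c3)c(=O)oc2c1C`, 730 nM
compound 3, `CC(C)=CCc1cc(C(=O)Nc2cc3ccc(OCCCNCC(N)=O)c(C)c3oc2=O)ccc1O`, 2290 nM

Among these three numbers compound 1 stands second highest. Its nearest neighbour is compound 2, a step of a 1.3-fold lower number from compound 1 to compound 2 (0.10 log units; within the scatter), which does not rise beyond the scatter. Its furthest neighbour is compound 3, with a 2.5-fold higher number from compound 1 to compound 3 (0.40 log units; beyond the scatter), a modest step beyond the scatter. Between the two open-chain compounds the step of a 3.1-fold higher number from compound 2 to compound 3 (0.50 log units; beyond the scatter) points the same way.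

Compound 4, `CC(C)=CCc1cc(C(=O)Nc2cc3ccc(OCCCNCCO)c(C)c3oc2=O)ccc1O`, has not yet been measured. It differs from compound 1 as follows: 2-((2-hydroxyethyl)amino)ethyl in place of 1-methylpyrrolidin-3-yl on a saturated chain carbon bound to an oxygen on an aromatic ring. Among the compounds with values here, the change is closest in kind to the one from compound 1 to compound 3, where an open chain carrying a secondary amine and hydrogen-bond donors also replaced the 1-methylpyrrolidin-3-yl group, and that step was modest and unfavourable; the step from compound 1 to compound 2, which kept a tertiary amine, stayed within the scatter. A modest rise in this assay is therefore expected for compound 4, though one somewhat smaller than that seen for compound 3, since a single hydroxyl rather than a carbamoyl group enters. The estimate for compound 4 is 1700 nM, within a range of 900 nM to 3300 nM, corresponding to an expected step of a 1.8-fold higher number from compound 1 to compound 4 (0.27 log units; within the scatter).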

Compound 4, half-maximal inhibitory concentration: 610 nM
Compound 4: middle estimate off by 2.8-fold (0.45 log units), on the high side; the measured number lies below the stated range.
By their numbers in this assay, from the lowest: compounds 4, 2 and 1 (each within the scatter of the next); then compound 3.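

In this assay, the open chain of compound 4 stands in place of the 1-methylpyrrolidin-3-yl group with a step that stays within the scatter (a 1.5-fold lower number from compound 1 to compound 4 (0.18 log units; within the scatter)), and its (2-hydroxyethyl)amino group likewise cannot be told apart from the ethyl(methyl)amino group of compound 2 (a 1.2-fold lower number from compound 2 to compound 4 (0.08 log units; within the scatter)). An open chain at this position, even one carrying hydrogen-bond donors, therefore does not by itself raise the number, as compound 3 alone had left possible. What separates the two compounds with a secondary amine on this chain is the group on the saturated chain carbon bound to the amine nitrogen, where hydroxymethyl in place of carbamoyl gives a modest step beyond the scatter (a 3.8-fold lower number from compound 3 to compound 4 (0.57 log units; beyond the scatter)), although nothing here explains this difference.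

As far as these compounds go, it remains open whether a carboxylic acid or a methoxymethyl group in place of hydroxymethyl would keep the number near that of compound 4 or move it toward that of compound 3. From the compounds shown here alone, it is equally open whether a longer chain between the amine nitrogen and the hydroxyl would be tolerated at this position.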